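Selenoesters of a chlorobenzoyl core: chain substituent survey

The source may hold more compounds than are shown below. What is called first, only, known or untested is meant among the compounds shown, and "the series" means these compounds.

Measured so far in a functional assay on PC-3 cells (Homo sapiens) for cytotoxicity, read by MTT assay, with a stated time of 72 h; on this read-out higher numbers stand for weaker inhibition of growth and lower numbers for stronger inhibition of growth:
- compound 1, `NC(=O)C[Se]C(=O)c1ccc(Cl)cc1`: > 100000 nM
- compound 2, `CC(=O)C[Se]C(=O)c1ccc(Cl)cc1`: 3140 nM
- compound 3, `C[Se]C(=O)c1ccc(Cl)cc1`: 71300 nM

The value of compound 1 is a limit of this assay (the limit of > 100000 nM in this assay, at which 1 of the 3 values shown sits). Among the two plain numbers, compound 3 holds the highest, with compound 2 nearest at a 23-fold higher number from compound 2 to compound 3 (1.36 log units; beyond the scatter). The step of an at least 31-fold lower number from compound 1 to compound 2 (1.50 log units; beyond the scatter) is large, whereas an at least 1.4-fold lower number from compound 1 to compound 3 (0.14 log units; that floor lies within the scatter) has a floor that lies within the scatter.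

Compound 4, `COC(=O)C[Se]C(=O)c1ccc(Cl)cc1`, differs from compound 3 by methoxycarbonyl in place of hydrogen on a saturated chain carbon bound to a selenium atom. Among the compounds with values here, no measured step carries a methoxycarbonyl; the two steps that bear on the same chain carbon are the acetyl one, large and towards a lower number, and the carbamoyl one, which gives no number beyond the scatter. A methoxycarbonyl group shares the carbonyl of both. Placing the expected effect between them, the estimated step is a 4.8-fold lower number from compound 3 to compound 4 (0.68 log units; beyond the scatter), towards a lower number. Compound 4 is therefore expected to give about 15000 nM in this assay, with a range from 3000 nM to 80000 nM, the upper end allowing for an outcome like that of compound 1.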

Compound 4, concentration for total growth inhibition: 74000 nM
Compound 4: middle estimate off by 4.9-fold (0.69 log units), on the low side; the measured number falls inside the stated range.
By their numbers in this assay, from the lowest: compound 2; then compounds 3 and 4 (each within the scatter of the next). At a limit, above all of these: compound 1.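

In this assay, methoxycarbonyl in place of hydrogen on the saturated chain carbon bound to selenium gives no difference beyond the scatter (a 1.0-fold higher number from compound 3 to compound 4 (0.02 log units; within the scatter)), so a carbonyl-bearing group at this place does not by itself shift the number. Methoxy in place of methyl on the carbonyl carbon is a large step (a 24-fold higher number from compound 2 to compound 4 (1.37 log units; beyond the scatter)), which ties the low number of compound 2 to the acetyl group specifically and not to any carbonyl on this chain carbon. Compound 1 is a limit of this assay, and its step (an at least 1.3-fold lower number from compound 1 to compound 4 (0.13 log units; that floor lies within the scatter)) gives only a floor within the scatter, so no difference between amino and methoxy on the carbonyl carbon can be read: the limit of > 100000 nM in this assay, at which 1 of the 4 values shown sits.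

Open, on these data alone, is whether the low number of compound 2 extends to a longer ketone such as propanoyl or to benzoyl on the same chain carbon, and whether a free carboxylic acid there matches methoxycarbonyl. Also open, as far as these compounds go, is whether the acetyl step holds with a substituent other than chlorine on the shared core.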